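Aryl sulfonate antiproliferatives: iodo for isopropyl, second occurrence

The compounds below may be only part of what the source reports. "The series", "measured", "known", "first", "only" and "open" are said of these compounds alone.

Compound 1 `CCC(=O)Nc1ccc(S(=O)(=O)Oc2ccccc2C(C)C)cc1` is the reference point of this small set; in a functional assay on MCF7 cells (Homo sapiens) for antiproliferative activity, read by sulforhodamine B assay, with a stated time of 48 h (on this read-out lower numbers stand for stronger inhibition and higher numbers for weaker inhibition), compound 1 gives 11000 nM. Compound 2 `CCC(=O)Nc1ccc(S(=O)(=O)Oc2ccccc2I)cc1` differs from it by iodo in place of isopropyl on an aromatic carbon and in this assay compound 2 gives 8100 nM, the step being a 1.4-fold lower number from compound 1 to compound 2 (0.13 log units; within the scatter). Compound 3 `CC(C)c1ccccc1OS(=O)(=O)c1ccc(NC(=O)NCC2CCCC2)cc1` keeps the isopropyl group and changes the acyl side; in this assay compound 3 gives 7100 nM, and the step is a 1.5-fold lower number from compound 1 to compound 3 (0.19 log units; within the scatter). All three numbers lie within the usual scatter of one another, so no order among them is claimed and none is called the most or least active.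

Compound 4 `O=C(NCC1CCCC1)Nc1ccc(S(=O)(=O)Oc2ccccc2I)cc1` has not yet been measured in this assay. It differs from compound 3 by iodo in place of isopropyl on an aromatic carbon. This is the same change that was made from compound 1 to compound 2, on a place described in the same words, and it occurs twice in all among these four compounds. The core of compound 3, on which the change is now made, differs from the core of compound 1 by (cyclopentylmethyl)amino in place of ethyl on a carbonyl carbon.

Because a 1.4-fold lower number from compound 1 to compound 2 (0.13 log units; within the scatter) stayed within the scatter, the expected step on the second core is of similar small size, a 1.3-fold lower number from compound 3 to compound 4 (0.11 log units; within the scatter). Compound 4 is estimated at 5500 nM, with a plausible range from 2500 nM to 12000 nM.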

Compound 4, half-maximal inhibitory concentration: 6600 nM
Beside the measured number, compound 4's estimate is 1.2-fold (0.08 log units) below it, and the stated range covers the measured number.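

In this assay, iodo in place of isopropyl on an aromatic carbon on the core of compound 3 gives a 1.1-fold lower number from compound 3 to compound 4 (0.03 log units; within the scatter), and this step agrees with the one seen on the core of compound 1: the same change on two cores in this assay, a 1.4-fold lower number (0.13 log units; within the scatter) from compound 1 to compound 2 and a 1.1-fold lower number (0.03 log units; within the scatter) from compound 3 to compound 4, 1.3-fold (0.10 log units) apart, within the scatter of two such steps. The other change, (cyclopentylmethyl)amino in place of ethyl on a carbonyl carbon, read with iodo in place gives a 1.2-fold lower number from compound 2 to compound 4 (0.09 log units; within the scatter), and it agrees in the same way with its counterpart read with isopropyl in place: the same change on two cores in this assay, a 1.5-fold lower number (0.19 log units; within the scatter) from compound 1 to compound 3 and a 1.2-fold lower number (0.09 log units; within the scatter) from compound 2 to compound 4, 1.3-fold (0.10 log units) apart, within the scatter of two such steps. Across these four compounds, each change carries from one core to the other with no detectable difference, but every step lies within the scatter, so what carries over is only the absence of a clear effect, not a step of known size, and it does not show that either change lowers the number.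

Open, going by these compounds, is whether another group on that aromatic carbon, such as a methoxy group, a carboxylic acid or an amine, would give a step beyond the scatter on either core. Also open, on these data alone, is whether a longer chain or a morpholine on the carbonyl carbon would behave alike with isopropyl and with iodo in place.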